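The source may report more compounds than this note shows. Statements on the series, on what has been measured and on what is new or still open speak of the compounds shown alone.

Measured compounds in a functional assay (Mus musculus, strain Balb/c) for inhibition, read by ELISA, with a stated time of 72 h; a lower number here means a stronger inhibitor, a higher number a weaker inhibitor:
compound 1 `O/N=C(\C=C\c1ccc(F)cc1)c1ccc(Cl)cc1` gives 10600 nM
compound 2 `COc1ccc(/C=C/C(=N\O)c2ccc(Cl)cc2)cc1` gives 5850 nM
compound 3 `O/N=C(\C=C\c1ccc(F)cc1)c1ccc(Br)cc1` gives 13300 nM

Compound 4 `COc1ccc(/C=C/C(=N\O)c2ccc(Br)cc2)cc1` is not yet measured. Its core is that of compound 3, which differs from the core of compound 1 by bromo in place of chloro on an aromatic carbon; that change gave a 1.3-fold higher number from compound 1 to compound 3 (0.10 log units; within the scatter). Compound 2 differs from compound 1 by methoxy in place of fluoro on an aromatic carbon, and the step was a 1.8-fold lower number from compound 1 to compound 2 (0.26 log units; within the scatter). The change from compound 3 to compound 4 is the same one, (methoxy in place of fluoro on an aromatic carbon), at the same place. Going by the values given here, with only this single earlier step to rest on, the step is expected to be of a similar size, a 1.8-fold lower number from compound 3 to compound 4 (0.25 log units; within the scatter), because the earlier one gave a 1.8-fold lower number from compound 1 to compound 2 (0.26 log units; within the scatter). Compound 4 is therefore estimated at 7400 nM in this assay, with a range from 3500 nM to 15000 nM.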

Compound 4, half-maximal inhibitory concentration: < 5000 nM
Compound 4: only a limit was reported; the forecaster's own chance of this, stated with the estimate: 5%; at least 1.4-fold (0.17 log units) between middle value and limit.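

In this assay compound 4 gives < 5000 nM, which is a limit and not a number. Methoxy in place of fluoro on an aromatic carbon gives an at least 2.6-fold lower number from compound 3 to compound 4 (0.42 log units; beyond the scatter) on the core of compound 3, so the change again goes with a lower number, but its size on the two cores cannot be compared: the same change on two cores in this assay, a 1.8-fold lower number (0.26 log units; within the scatter) from compound 1 to compound 2 and an at least 2.6-fold lower number (0.42 log units; beyond the scatter) from compound 3 to compound 4; the limit leaves it open whether they differ. Bromo in place of chloro on an aromatic carbon gives an at least 1.1-fold lower number from compound 2 to compound 4 (0.06 log units; that floor lies within the scatter) and does not show whether this change carries from one core to the other: the same change on two cores in this assay, a 1.3-fold higher number (0.10 log units; within the scatter) from compound 1 to compound 3 and an at least 1.1-fold lower number (0.06 log units; that floor lies within the scatter) from compound 2 to compound 4; the limit leaves it open whether they differ.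

Open, going by these compounds, is how an amine or a trifluoromethyl group would read in place of methoxy on the same ring. Also open, on these data alone, is where compound 4 lies beyond its limit.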